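A few compounds are considered here, and "the series" means these few. Any claim that something is new, unique, unknown or untested is made for them only; others in the source may bear on it.

For the measured compounds named here, compound 2 `Cc1csc(C2=NNC(c3ccc(N4CCCCC4)cc3)C2)c1` gives 24400 nM in an ADME assay on PBMC cells (Homo sapiens) for cytotoxicity, with a stated time of 5 days; on this read-out higher numbers stand for weaker inhibition and lower numbers for stronger inhibition; its only neighbour in this assay, compound 1 `c1csc(C2=NNC(c3ccc(N4CCCCC4)cc3)C2)c1`, gives 20800 nM, and the two numbers sit within the scatter of each other. Going by the values given here, the step of a 1.2-fold higher number from compound 1 to compound 2 (0.07 log units; within the scatter), a methyl in place of hydrogen on an aromatic carbon, is the sole measured change and it moved nothing beyond noise. Compound 3 `Cc1ccc(C2=NNC(c3ccc(N4CCCCC4)cc3)C2)s1` keeps the same atoms, rearranged: 5-methylthiophen-2-yl in place of 4-methylthiophen-2-yl on a carbon with a double bond to nitrogen. Among the compounds with values here, no step for this rearrangement exists in the set, so the expectation rests on the flat step from compound 1 to compound 2 alone. For compound 3 the expected step is a 1.0-fold lower number from compound 2 to compound 3 (0.01 log units; within the scatter), none beyond the scatter. Compound 3 is therefore estimated at 24000 nM, with a range from 10000 nM to 55000 nM.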

Compound 3, half-maximal inhibitory concentration: 86400 nM
Compound 3: the middle estimate sits 3.6-fold (0.56 log units) below what was measured; the measured number lies above the stated range.
By their numbers in this assay, from the lowest: compounds 1 and 2 (each within the scatter of the next); then compound 3.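

The position of the methyl matters in this assay even with the atoms unchanged: 5-methylthiophen-2-yl in place of 4-methylthiophen-2-yl gives a 3.5-fold higher number from compound 2 to compound 3 (0.55 log units; beyond the scatter) and so moves the number beyond the scatter. Methyl in place of hydrogen is therefore not flat at every aromatic carbon, since it gives a 4.2-fold higher number from compound 1 to compound 3 (0.62 log units; beyond the scatter) here, while the same kind of change leading to compound 2 stays within the scatter. Nothing in hand accounts for this difference.

From the compounds shown here alone, it remains open whether ethyl, chlorine or a carboxylic acid in place of the methyl of 5-methylthiophen-2-yl would raise the number further. Going by these compounds, whether the shift carries over to cores with another group in place of the piperidine also remains open.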